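Tetramethyloxane series: unsaturation in the saturated ring

The source may report more compounds than this note shows. Statements on the series, on what has been measured and on what is new or still open speak of the compounds shown alone.

Compound 2 `COc1ccccc1-n1nc(C2CC(C)(C)OC(C)(C)C2)cc1-c1ccc(Cl)cc1` gives the lowest number of the three in an assay on HEK293 cells for inhibition of Voltage-dependent N-type calcium channel subunit alpha-1B (Homo sapiens), read by patch clamp, using a membrane potential dye (on this read-out higher numbers stand for weaker inhibition and lower numbers for stronger inhibition), at 16 nM. Compound 1 `COc1ccccc1-n1nc([C@@H]2CCO[C@H](C(C)C)C2)cc1-c1ccc(Cl)cc1` gives 55000 nM, and compound 3 `CCOc1ccc(-c2cc(C3CC(C)(C)OC(C)(C)C3)nn2-c2ccccc2OC)cc1` gives 29 nM. The step of a 3400-fold lower number from compound 1 to compound 2 (3.54 log units; beyond the scatter) is large; the step of a 1.8-fold higher number from compound 2 to compound 3 (0.26 log units; within the scatter) is not. Compound 4 `COc1ccccc1-n1nc(C2=CC(C)(C)OC(C)(C)C2)cc1-c1ccc(Cl)cc1` is not yet measured. It differs from compound 2 by a group of 10 heavy atoms (9 carbon, 1 oxygen; one six-membered non-aromatic ring with 1 hetero atom) in place of a group of 10 heavy atoms (9 carbon, 1 oxygen; one six-membered non-aromatic ring with 1 hetero atom), on an aromatic carbon. Among the compounds with values here, no measured step alters the saturated ring itself while keeping its four methyl groups; the one step at that position, from compound 1 to compound 2, exchanged the whole substitution pattern. The expected move in this assay is therefore a 1.9-fold higher number from compound 2 to compound 4 (0.27 log units; within the scatter), a step not beyond the scatter. Compound 4 is estimated at 30 nM, with a range from 8 nM to 120 nM.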

Compound 4, half-maximal inhibitory concentration: 26000 nM
Beside the measured number, compound 4's estimate is 870-fold (2.94 log units) below it; measured number above the stated range.
By their numbers in this assay, from the lowest: compounds 2 and 3 (each within the scatter of the next); then compound 4; then compound 1.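

With all four methyl groups kept, a single double bond outside aromatic rings at this position gives a 1600-fold higher number from compound 2 to compound 4 (3.21 log units; beyond the scatter) in this assay, so the low number depends on more than the tetramethyl substitution. The result also places the unsaturated ring only modestly ahead of the 2-isopropyloxan-4-yl ring, with a 2.1-fold lower number from compound 1 to compound 4 (0.33 log units; beyond the scatter) as the step. Nothing available accounts for the loss.

The compounds shown leave open whether a hydroxy group on the saturated ring would be accepted. Also open, from the compounds shown here alone, is whether an amine nitrogen could replace the ring oxygen.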